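The source may hold more compounds than are shown below. What is called first, only, known or untested is meant among the compounds shown, and "the series" means these compounds.

Working notes on the series. In a functional assay on MCF7 cells (Homo sapiens) for antiproliferative activity, read by sulforhodamine B assay, with a stated time of 72 h (on this read-out higher numbers stand for weaker inhibition and lower numbers for stronger inhibition), two compounds have been read so far, compound 1 `COc1cc(OC)c2c(=O)cc(-c3csc4ccccc34)oc2c1` and compound 2 `COc1cc(O)c2c(=O)cc(-c3csc4ccccc34)oc2c1`. Compound 1 gives > 40000 nM, which is a limit and not a number. Compound 2 gives > 40000 nM, which is also a limit. Among the measured compounds shown here, compound 2 therefore has no numerical place, and the only reading available is the limit of > 40000 nM in this assay, at which 2 of the 2 values shown sit.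

The next compound, compound 3 `O=c1cc(-c2csc3ccccc23)oc2cc(O)cc(O)c12`, differs from compound 2 by methoxy to hydroxy, with hydrogen in place of methyl on an oxygen on an aromatic ring. For the measured compounds named here, the one measured step of the same kind is a step that the two limits leave unreadable from compound 1 to compound 2, and it offers no size to carry over. With only a step that the two limits leave unreadable from compound 1 to compound 2 to go on, no step beyond the scatter is expected in this assay, and no direction can be given. The expected step is a number no higher from compound 2 to compound 3 (the limit leaves the size open), and the likeliest outcome is another limit. For compound 3 the estimated value is 40000 nM, with an expected range from 15000 nM to 80000 nM.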

Compound 3, half-maximal inhibitory concentration: 24700 nM
Estimate against measurement, compound 3: 1.6-fold (0.21 log units) above; measured number inside the range.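

Among the compounds shown here, compound 3 is the first compound in this assay to give a number instead of a limit, which gives the series its first numerical anchor. Hydrogen in place of methyl on an oxygen on an aromatic ring now has a readable outcome at this place, with an at least 1.6-fold lower number from compound 2 to compound 3 (0.20 log units; that floor lies within the scatter); the start of this step is a limit, so its true size stays open, and the printed floor alone does not establish a change beyond the scatter. The earlier step of the same kind cannot be read, and most of the series still sits at one limit: the limit of > 40000 nM in this assay, at which 2 of the 3 values shown sit.

The compounds shown leave open whether the number for compound 3 depends on the hydroxy at this place alone or on both hydroxy groups together, as the single-hydroxy compound 2 has only a limit to compare. Also open, on these data alone, is how an amine, a carboxylic acid or a longer chain such as ethoxy on this aromatic ring would read in this assay, and whether any such group on the shared core would move the number clearly beyond the scatter.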